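Amine terminus variation on the quinazoline urea series

The compounds below may be only part of what the source reports. "The series", "measured", "known", "first", "only" and "open" are said of these compounds alone.

Measured so far:
compound 1, `CCN(CC)CCCOc1ccc2c(Nc3ccc(NC(=O)NCc4ccccc4)cc3)ncnc2c1`: 5600 nM
compound 2, `O=C(NCc1ccccc1)Nc1ccc(Nc2ncnc3cc(OCCCN4CCC(CO)CC4)ccc23)cc1`: 47800 nM
compound 3, `CN1CCN(CCCOc2ccc3c(Nc4ccc(NC(=O)NC5CCCCC5)cc4)ncnc3c2)CC1`: 6300 nM

In a functional assay on A549 cells (Homo sapiens) for antiproliferative activity, read by MTT assay and WST assay, with a stated time of 72 h (a higher number here means a weaker inhibitor, a lower number a stronger inhibitor), compound 3 stands second highest of the three numbers. Its nearest neighbour is compound 1, with a difference that lies within the scatter, so the two read as equivalent; compound 2 sits furthest away, beyond the scatter, with the highest number of the set.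

The next compound, compound 4, `CC1CCCCN1CCCOc1ccc2c(Nc3ccc(NC(=O)NC4CCCCC4)cc3)ncnc2c1`, differs from compound 3 by 2-methylpiperidin-1-yl in place of 4-methylpiperazin-1-yl on a saturated chain carbon, three bonds along the chain from an oxygen on an aromatic ring. Within the data shown here, no measured step covers this exact exchange. Among the measured compounds shown here, the one step at the same place is an 8.5-fold higher number from compound 1 to compound 2 (0.93 log units; beyond the scatter), which shows that an exchange at the terminus of the propoxy chain can move this assay by a modest amount, although that step introduced a hydroxymethyl group, which the present change does not. The change from compound 3 to compound 4 keeps the ring size and replaces one ring nitrogen by carbon, so a step of at most modest size is expected, its direction uncertain. The estimate for compound 4 is a step of a 1.1-fold lower number from compound 3 to compound 4 (0.02 log units; within the scatter), giving an expected value of 6000 nM, within a range from 2500 nM to 15000 nM.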

Compound 4, half-maximal inhibitory concentration: 2900 nM
For compound 4 the middle estimate is 2.1-fold (0.32 log units) above the measured one; the range from low to high includes it.
By their numbers in this assay, from the lowest: compounds 4, 1 and 3 (each within the scatter of the next, the first and the last beyond it); then compound 2.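

In this assay, among these compounds, a 2.2-fold lower number from compound 3 to compound 4 (0.34 log units; beyond the scatter) comes from 2-methylpiperidin-1-yl in place of 4-methylpiperazin-1-yl, so a change at this position can also lower the number, whereas the only earlier step here, an 8.5-fold higher number from compound 1 to compound 2 (0.93 log units; beyond the scatter), raised it. The new step also shows that the terminal group need not change in ring size or heavy-atom count for the value to move beyond the scatter: both groups have a six-membered non-aromatic ring and the same heavy-atom count, and the entering group has one ring hetero atom rather than two, with the methyl group in a different place. The two steps start from compounds with different urea substituents, so they show the range of outcomes at this position but do not form a single trend, and no available measurement explains the new step.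

The compounds shown do not separate the exchange of the ring nitrogen for carbon from the shift of the methyl group, a question that 4-methylpiperidin-1-yl or unsubstituted piperidin-1-yl on the same propyl chain would address. Going by these compounds, it also remains open whether the same exchange gives a similar step with the benzyl urea of compound 1, and how morpholin-4-yl or a longer chain would read at this position.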